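The compounds below may be only part of what the source reports. "The series", "measured", "known", "first", "only" and "open" are said of these compounds alone.

Within the data shown here, in a functional assay on MDA-MB-231 cells (Homo sapiens) for antiproliferative activity, read by MTT assay, with a stated time of 72 h (a lower number here means a stronger inhibitor, a higher number a weaker inhibitor), compound 3 `COc1cc(OC)cc(-c2cccc(NC(=O)CCc3cccc4c3COB4O)c2)c1` gives 93000 nM, the highest number of the three measured so far. Compound 2 `COc1cc(OC)cc(-c2cccc(NC(=O)CCc3ccc4c(c3)B(O)OC4)c2)c1` gives 21000 nM, and compound 1 `COc1cc(OC)cc(-c2cccc(NC(=O)CCc3cccc4c3B(O)OC4)c2)c1` gives 40 nM. All three carry a boron-containing group of the same size, arranged differently. Compound 4 `COc1cc(OC)cc(-c2cccc(NC(=O)CCc3ccccc3)c2)c1` gives up that group for phenyl: a group of 6 heavy atoms (6 carbon; one six-membered aromatic ring of carbon only) in place of a group of 10 heavy atoms (7 carbon, 1 boron, 2 oxygen; one five-membered non-aromatic ring with 2 hetero atoms, one six-membered aromatic ring of carbon only), on a saturated chain carbon, two bonds along the chain from a carbonyl carbon. Among the measured compounds shown here, no measured step removes the group, so the evidence is indirect. The closest guides are a 2300-fold higher number from compound 1 to compound 3 (3.37 log units; beyond the scatter), which is large, and a 4.4-fold higher number from compound 2 to compound 3 (0.65 log units; beyond the scatter), which is modest, while a 530-fold higher number from compound 1 to compound 2 (2.72 log units; beyond the scatter) is also large. Only compound 1 reaches a low number, and compound 4 lacks its group, so the weak end is the likelier home. The expected step is a 1.3-fold lower number from compound 3 to compound 4 (0.12 log units; within the scatter), and no change beyond the scatter is expected in this assay. For compound 4 the estimated value is 70000 nM, with an expected range of 20000 nM to 200000 nM.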

Compound 4, half-maximal inhibitory concentration: 87000 nM
Estimate against measurement, compound 4: 1.2-fold (0.09 log units) below; measured number inside the range.
By their numbers in this assay, from the lowest: compound 1; then compound 2; then compounds 4 and 3 (each within the scatter of the next).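

Phenyl gives the comparison that the boron-containing compounds lacked: a 1.1-fold lower number from compound 3 to compound 4 (0.03 log units; within the scatter) lies within the scatter, so the boron-containing group of compound 3 shows no gain over plain phenyl on this saturated chain carbon. Against phenyl, a 4.1-fold higher number from compound 2 to compound 4 (0.62 log units; beyond the scatter) is modest and a 2200-fold higher number from compound 1 to compound 4 (3.34 log units; beyond the scatter) is large, so the clear gain belongs to the arrangement in compound 1. No evidence here says why the arrangements differ.

From the compounds shown here alone, whether a carboxylic acid or an amine on this chain could match the group of compound 1 stays open. So does whether that group would keep its low number on a longer chain.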